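The source may hold more compounds than are shown below. What is called first, only, known or untested is meant among the compounds shown, and "the series" means these compounds.

Two compounds carry the same core, a tetrazole joined through a three-carbon chain to an oxygen on a benzene ring, which in turn is linked through another oxygen to a second ring system. Compound 1 `c1ccc2[nH]c(COc3ccc(OCCCc4nnn[nH]4)cc3)nc2c1` gives 42% in a functional assay (Cavia porcellus) for inhibition of cysteinyl leukotriene receptor (Homo sapiens), tested at 10 uM; a lower number here means less inhibition, a higher number more inhibition at the concentration tested (going by the name of the read-out). Compound 2 `CCOC(=O)c1ccc(COc2ccc(OCCCc3nnn[nH]3)cc2)nc1` gives 41% in this assay. Of the two numbers, compound 2 has the lower one, but its nearest neighbour is compound 1: compound 1 gives 42% and compound 2 gives 41%, a gap within the usual scatter, so the two cannot be told apart.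

Compound 3 `O=C(O)c1ccc(COc2ccc(OCCCc3nnn[nH]3)cc2)nc1` has not yet been measured in this assay. It differs from compound 2 in one place: hydrogen in place of ethyl on an oxygen next to a carbonyl group. For the measured compounds named here, no pair of measured compounds shows a step of this kind, so there is no recorded step to lean on. The expectation is a step from compound 2 to compound 3 of a number 4 percentage points higher from compound 2 to compound 3 (within the scatter) in this assay, which is no more than the scatter in either direction. Compound 3 is therefore expected to give about 45%, with a likely range from 20% to 70%.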

Compound 3, a percentage reported as inhibition, at one concentration (the size of the read-out at that concentration, not a potency): 22%
Compound 3: middle estimate off by 23 percentage points, on the high side; the range from low to high includes it.
By their numbers in this assay, from the lowest: compound 3; then compounds 2 and 1 (each within the scatter of the next).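

In this assay, putting hydrogen in place of ethyl on an oxygen next to a carbonyl group gives a number 19 percentage points lower from compound 2 to compound 3 (beyond the scatter), so this place in the molecule does respond to a change. The two earlier compounds could not show this, since they differ in more than one place and no single change could be read from them; this pair turns an ethoxycarbonyl group into a carboxy group and changes nothing else, which ties the drop to that one swap. Nothing measured here bears on what lies behind the drop.

A single pair cannot separate the loss of the ethyl group from the arrival of the carboxy group, and a methyl ester, a longer chain on the same oxygen or a primary amide in the same place would help to tell these apart. From the compounds shown here alone, it also remains open whether the same swap would do the same on another core, such as that of compound 1, and how the step would look as a potency, since these numbers come from one concentration only.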